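The source may report more compounds than this note shows. Statements on the series, on what has been measured and on what is new or still open speak of the compounds shown alone.

Compound 2 `Cn1c(=O)c(S(=O)(=O)Cc2ccc(F)cc2)cc2cnc(Nc3ccc4[nH]ccc4c3)nc21` stands at the weak end of the three measured compounds in a functional assay on DU-145 cells (Homo sapiens) for inhibition, read by trypan blue exclusion, with a stated time of 72 h (on this read-out higher numbers stand for weaker inhibition and lower numbers for stronger inhibition), where compound 2 gives 30000 nM. Compound 1 `Cn1c(=O)c(S(=O)(=O)c2ccc(F)cc2)cc2cnc(Nc3ccc4cc[nH]c4c3)nc21` gives 10000 nM in this assay, and compound 3 `Cn1c(=O)c(S(=O)(=O)c2ccc(F)cc2F)cc2cnc(Nc3ccc4sccc4c3)nc21` gives 500 nM; both gaps to compound 2 lie beyond the scatter. Compound 4 `Cc1ccc(S(=O)(=O)c2cc3cnc(Nc4ccc5[nH]ccc5c4)nc3n(C)c2=O)cc1` has not yet been measured. It differs from compound 2 in one place: 4-methylphenyl in place of 4-fluorobenzyl on a sulfonyl sulfur. Since compound 1 gives 10000 nM in this assay with an aromatic ring on its sulfonyl sulfur, a step toward stronger inhibition is expected from compound 2 to compound 4, a 3.8-fold lower number from compound 2 to compound 4 (0.57 log units; beyond the scatter), beyond the scatter. In this assay compound 4 is estimated at 8000 nM, with a range from 2000 nM to 30000 nM.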

Compound 4, half-maximal inhibitory concentration: 750 nM
Estimate against measurement, compound 4: 11-fold (1.03 log units) above; measured number below the stated range.
By their numbers in this assay, from the lowest: compounds 3 and 4 (each within the scatter of the next); then compound 1; then compound 2.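

In this assay, the change of group on the sulfonyl sulfur gives a 40-fold lower number from compound 2 to compound 4 (1.60 log units; beyond the scatter), showing that this position alone can shift the number by a large margin while the rest of the structure stays the same. The step exchanges 4-fluorobenzyl for 4-methylphenyl as whole groups, so it cannot show which part of that difference matters. Nothing measured here accounts for the size of the step. From the compounds shown here alone, it remains open how phenyl, a longer chain such as 2-phenylethyl, or an amine such as dimethylamino would behave on the sulfonyl sulfur.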